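The source may report more compounds than this note shows. Statements on the series, on what has been measured and on what is new or still open speak of the compounds shown alone.

In a physicochemical assay for solubility, using the shake flask method, in simulated intestinal fluid, measured as kinetic solubility, with a stated time of 20 h, at pH 6.5 (on this read-out lower numbers stand for lower solubility and higher numbers for higher solubility), compound 1 (`FC(F)(F)c1ccc(Nc2cc3[nH]c(-c4cccc(C(F)(F)F)c4)nc3cn2)nc1`) gives >= 50000 nM, which is a limit of the assay and not a number. That limit (the limit of >= 50000 nM in this assay, at which 1 of the 3 values shown sits) places compound 1 highest of the three measured compounds. Compound 2 (`O=C(O)c1ccc(Nc2cc3[nH]c(-c4cccc(C(F)(F)F)c4)nc3cn2)nc1`) gives 6000 nM. Compound 3 (`CN1CCN(c2ccc(Nc3cc4[nH]c(-c5cccc(C(F)(F)F)c5)nc4cn3)nc2)CC1`) gives < 5000 nM, which is also a limit (the limit of < 5000 nM in this assay, at which 1 of the 3 values shown sits).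

Compound 4 (`FC(F)(F)c1ccc(Nc2cc3[nH]c(C4CCOC4)nc3cn2)nc1`) has oxolan-3-yl in place of 3-(trifluoromethyl)phenyl on an aromatic carbon of a five-membered aromatic ring with 2 nitrogen, between two ring nitrogen atoms: oxolan-3-yl in place of 3-(trifluoromethyl)phenyl on an aromatic carbon.

Two measured steps start from compound 1. They are an at least 8.3-fold lower number from compound 1 to compound 2 (0.92 log units; beyond the scatter) and an at least 10-fold lower number from compound 1 to compound 3 (1.00 log units; beyond the scatter), and both lie beyond the scatter. The remaining step, an at least 1.2-fold lower number from compound 2 to compound 3 (0.07 log units; that floor lies within the scatter), has a floor within the scatter. All three steps change the group at the other end of the molecule, and the 3-(trifluoromethyl)phenyl group is common to all three measured compounds. Among the compounds with values here, no measured step therefore tests the present change, and the drops seen for compound 2 and compound 3 cannot simply be carried over.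

In this assay, no step beyond the scatter is expected, and the estimated step is an at least 1.2-fold lower number from compound 1 to compound 4 (0.09 log units; that floor lies within the scatter). Compound 4 is expected at 40000 nM, with an estimated range of 15000 nM to 60000 nM.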

Compound 4, solubility: 180000 nM
The estimate for compound 4 lay 4.5-fold (0.65 log units) below the measured number; measured number outside the range, above it.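

Compound 1 sits at a limit and not at a number in this assay, so the step to compound 4 cannot be read: the limit of >= 50000 nM in this assay, at which 1 of the 4 values shown sits.

The compounds shown leave open how large the change from 3-(trifluoromethyl)phenyl to oxolan-3-yl is, and whether it would be the same on compound 2 or compound 3.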